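A few compounds are considered here, and "the series" means these few. Any claim that something is new, unique, unknown or untested is made for them only; others in the source may bear on it.

Of the compounds shown here, two have so far been read in a physicochemical assay for solubility, read by nephelometry, in phosphate buffer, measured as kinetic solubility, at pH 6.5; a higher number here means a more soluble compound, a lower number a less soluble compound. Compound 1 (`Cc1cc(C(=O)NNS(=O)(=O)c2ccccc2F)cc(-c2ccccn2)c1`) gives 12.5 ug/mL. Compound 2 (`Cc1cc(-c2ncccn2)cc(C(=O)NNS(=O)(=O)c2ccccc2)c1F`) gives 50 ug/mL, the higher of the two numbers, and the gap between them lies beyond the scatter of repeated measurements. Compound 3 (`Cc1cc(-n2nccn2)cc(C(=O)NNS(=O)(=O)c2ccccc2)c1F`) has not yet been measured. It keeps the rest of compound 2 and carries 2H-1,2,3-triazol-2-yl in place of pyrimidin-2-yl on an aromatic carbon, para to a fluoro group and meta to a methyl group: 2H-1,2,3-triazol-2-yl in place of pyrimidin-2-yl on an aromatic carbon. Going by the values given here, no measured pair shows this change, and the expectation rests on the structural change alone. The step expected in this assay is small and downward, a 1.4-fold lower number from compound 2 to compound 3 (0.15 log units; within the scatter), and it is estimated to stay within the scatter. The expected solubility of compound 3 is 35 ug/mL, with an estimated range from 12 ug/mL to 90 ug/mL.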

Compound 3, solubility: 25 ug/mL
Estimate against measurement, compound 3: 1.4-fold (0.15 log units) above; measured number inside the range.
By their numbers in this assay, from the lowest: compounds 1, 3 and 2 (each within the scatter of the next, the first and the last beyond it).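

In this assay, going by these compounds alone, the change from pyrimidin-2-yl to 2H-1,2,3-triazol-2-yl gives a 2.0-fold lower number from compound 2 to compound 3 (0.30 log units; within the scatter) and is the first single change read at this position, an aromatic carbon para to a fluoro group and meta to a methyl group. A five-membered aromatic ring with 3 hetero atoms thus stands here in place of a six-membered aromatic ring with 2 hetero atoms, and the reading does not separate compound 2 from compound 3. Nothing at hand accounts for this result.

On these data alone, what an amine, a carboxylic acid or a longer chain on this same aromatic carbon would give remains open. Also open, as far as these compounds go, is whether this change would read alike on another core, since compound 1 differs from compound 2 in more than one place and offers no such comparison.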